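Extending the hydroxamic chain of a chlorinated benzothiazole thioether

A few compounds are considered here, and "the series" means these few. Any claim that something is new, unique, unknown or untested is made for them only; others in the source may bear on it.

Compound 1 `CN(O)C(=O)CCSc1nc2ccccc2s1`: 39 nM
Compound 2 `CN(O)C(=O)CCSc1nc2cc(Cl)ccc2s1`: 20 nM
Compound 3 `CN(O)C(=O)NCSc1nc2ccccc2s1`: 1070 nM

In a functional assay for inhibition of Polyunsaturated fatty acid 5-lipoxygenase (Homo sapiens) (a lower number here means that less compound is needed, a higher number that more compound is needed for the effect), compound 2 gives the lowest of the three numbers. Its nearest neighbour is compound 1, and the step of a 2.0-fold lower number from compound 1 to compound 2 (0.29 log units; within the scatter) lies within the scatter, so the two cannot be ordered. Compound 3, in this assay, stands far away with 1070 nM, a gap well beyond the scatter.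

Compound 4 `CN(O)C(=O)NCCSc1nc2cc(Cl)ccc2s1` differs from compound 2 in one place: (hydroxy(methyl)carbamoyl)amino in place of hydroxy(methyl)carbamoyl on a saturated chain carbon, two bonds along the chain from a sulfur. Within the data shown here, no measured step covers exactly this change. Among the measured compounds shown here, the only measured step, from compound 1 to compound 2, concerns the chloro substituent and does not bear on it. Compound 1 and compound 3 differ in more than one place, so their values show only that a nitrogen-linked variant with a shorter chain gives a much higher number than the carbon-linked one.

On this thin basis compound 4 is expected to give a higher number than compound 2, with the estimated step of a 13-fold higher number from compound 2 to compound 4 (1.10 log units; beyond the scatter). The estimate for compound 4 in this assay is 250 nM, with a range from 50 nM to 1200 nM.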

Compound 4, half-maximal effective concentration: 20 nM
The estimate for compound 4 lay 13-fold (1.10 log units) above the measured number; measured number outside the range, below it.
By their numbers in this assay, from the lowest: compounds 2, 4 and 1 (each within the scatter of the next); then compound 3.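

In this assay, the step of no change at the digits printed from compound 2 to compound 4 (within the scatter) shows that the place on a saturated chain carbon, two bonds along the chain from a sulfur, accepts (hydroxy(methyl)carbamoyl)amino in place of hydroxy(methyl)carbamoyl without a readable shift in the number, although the entering group has 6 heavy atoms against 5 and 2 hydrogen-bond donors against 1. Among these compounds, until now the only nitrogen-linked example was compound 3 at 1070 nM in this assay, and it differs from the other compounds in more than one place, so the new pair is the first to isolate this exchange and shows that a nitrogen-linked group does not by itself bring a high number. No measurement at hand offers an explanation for this result.

On these data alone, what sets compound 3 so far from compound 4 stays open, since the two differ in both the chain and the chloro substituent. Also open, as far as these compounds go, is how a longer chain ahead of the (hydroxy(methyl)carbamoyl)amino group, or a carboxylic acid at the same place, would read in this assay on the shared core.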